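Side-chain exchange on the acid of compound 1

This account rests on a few compounds, and the source may have more. Where it says the series, first, only, none or still open, it means among the compounds named here.

Measured in a functional assay on the whole organism (Tail, strain ICR) with Mus musculus as the target, in the tail flick test, with a stated time of 60 min, at a dose of 25 umol/kg by the oral route; a higher number here means a stronger effect of the compound at the dose given, a lower number a weaker effect:
compound 1 `N=C(N)NCCC[C@H](NC(=O)CN(c1nc(Cl)nc2[nH]cnc12)C1CC1)C(=O)O` gives 51%
compound 2 `N=C(N)NCCC[C@H](NC(=O)CN(c1nc(Cl)nc2[nH]cnc12)C1CC1)C(=O)OCc1ccccc1` gives 30.6%
compound 3 `CC[C@H](C)[C@H](NC(=O)CN(c1ncnc2c1ncn2C1CCCCO1)C1CC1)C(=O)OCc1ccccc1` gives 27.4%

Compound 1 stands highest of the three numbers; compound 2 lies nearest, compound 3 furthest, both steps beyond the scatter. For the measured compounds named here, the one single-point step measured so far is a number 20.4 percentage points lower from compound 1 to compound 2 (beyond the scatter), a benzyl in place of hydrogen on the oxygen next to the carbonyl group. Compound 3 differs from both in several places at once, so its value shows only that a branched chain with the other core variant sits in the same low band as compound 2.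

Compound 4 `CSCC[C@H](NC(=O)CN(c1nc(Cl)nc2[nH]cnc12)C1CC1)C(=O)O` keeps the free acid and the core of compound 1 and changes only the side chain: a group of 2 heavy atoms (1 carbon, 1 sulfur; no ring) in place of a group of 5 heavy atoms (2 carbon, 3 nitrogen; no ring), on a saturated chain carbon, three bonds along the chain from an amide-type nitrogen and a carbonyl carbon. Going by the values given here, no measured step touches this position, so the benzyl step of compound 2 gives no direct guide. With no side-chain comparison available, the expectation for compound 4 is a modest loss, estimated as a number 13 percentage points lower from compound 1 to compound 4 (beyond the scatter). Compound 4 is expected to give 38%, with a range from 18% to 55%.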

Compound 4, a percentage reported as activity, at one dose (the size of the read-out at that dose, not a potency): 22.8%
Estimate against measurement, compound 4: 15.2 percentage points above, and the stated range covers the measured number.
By their numbers in this assay, from the lowest: compounds 4, 3 and 2 (each within the scatter of the next); then compound 1.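

In this assay, exchanging the side chain while the free acid and the core of compound 1 stay fixed gives a number 28.2 percentage points lower from compound 1 to compound 4 (beyond the scatter) and so the read-out at this dose depends on this position. For the compounds shown here, this is the first measured step on this saturated chain carbon, and it shows that the read-out responds to the side chain as well as to the benzyl on the acid oxygen. With methylsulfanyl in place, the group of compound 1 is not matched, but nothing at hand explains the loss.

Going by these compounds, whether a primary amine or a longer chain ending in a carboxylic acid on this carbon would restore the read-out of compound 1 stays open. Also open, on these data alone, is whether a benzyl on the acid oxygen would change the read-out of compound 4 as it does that of compound 1.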